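Vero tolerance in this series: chloro to hexylamino

The source may report more compounds than this note shows. Statements on the series, on what has been measured and on what is new or still open speak of the compounds shown alone.

Measured so far:
compound 1 `CCCCCCCCNc1nccnc1C(=O)NCc1ccccc1` — > 100000 nM
compound 2 `O=C(NCc1ccccc1)c1nccnc1Cl` — "not determined" (no result reported)

In an ADME assay on Vero cells (Chlorocebus sabaeus) for cytotoxicity, read by microscopy, with a stated time of 6 days (a higher number here means that more compound is tolerated, a lower number that less compound is tolerated), compound 1 gives > 100000 nM, which is a limit of the assay rather than a number. Among the measured compounds shown here, for compound 2 this assay reports "not determined" (no result reported), so compound 2 stands without any number of its own; the only value shown in the set is the limit of > 100000 nM in this assay, at which 1 of the 2 values shown sits. Compound 3 `CCCCCCNc1nccnc1C(=O)NCc1ccccc1` differs from compound 2 by hexylamino in place of chloro on an aromatic carbon. For the measured compounds named here, no measured step exists between these compounds, so neither size nor direction of the step in this assay can be read from the data, and no shift beyond the scatter is expected. The expectation for compound 3 rests on compound 1, whose value > 100000 nM is a limit. Compound 3 is estimated at 100000 nM, with a range from 30000 nM to 200000 nM.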

Compound 3, minimum cytotoxic concentration: > 100000 nM
Compound 3 was reported as a limit; the forecaster's own chance of this, stated with the estimate: 70%; the middle value sits exactly at the limit.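

No step can be read from compound 1 to compound 3: in this assay both stand as limits. The compounds shown leave open at what concentration either chain becomes cytotoxic, and where compound 2 with its chloro stands.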